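Swapping Bromo for Chloro on a Shared Core

The source may hold more compounds than are shown below. What is called first, only, known or untested is meant among the compounds shown, and "the series" means these compounds.

Measured compounds and their values in a physicochemical assay for pharmacokinetics, read by LC-MS, in phosphate buffer, at pH 7.4, in the presence of a further agent that is not named here; on this read-out higher numbers stand for a longer-lived compound and lower numbers for a shorter-lived compound:
- compound 1 `C=CC(=O)N1CC(NC(=O)Cn2c(C)c(C(=O)N3CCc4c(cccc4OC)C3)c3cc(Br)cc(C)c32)C1`: 1.67 h
- compound 2 `C=CC(=O)N1CC(NC(=O)Cn2cc(C(=O)N3CCc4c(Cl)cccc4C3)c3cc(Br)ccc32)C1`: 1.67 h
- compound 3 `C=CC(=O)N1CC(NC(=O)Cn2c(C)c(C(=O)N3CCc4c(cccc4OC)C3)c3cc(Br)ccc32)C1`: 1.67 h

Compound 1 stands level with compounds 2 and 3 at the digits shown; all three fall within the usual scatter of one another, so no ordering among them can be read. Among the compounds with values here, the only single-point step measured, no change at the digits printed from compound 1 to compound 3 (within the scatter), left the half-life unchanged within the scatter.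

Compound 4 `C=CC(=O)N1CC(NC(=O)Cn2c(C)c(C(=O)N3CCc4c(cccc4OC)C3)c3cc(Cl)cc(C)c32)C1` differs from compound 1 by chloro in place of bromo on an aromatic carbon. Within the data shown here, no measured step swaps one of these two groups for the other, so no direct precedent exists; the one measured step near this position showed no movement. In this assay compound 4 is therefore expected to sit at the same level, the estimated step of no change at the digits printed from compound 1 to compound 4 (within the scatter) being within the scatter. The estimate for compound 4 is 1.67 h, with a range from 0.9 h to 3.2 h.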

Compound 4, half-life: 1.67 h
The estimate for compound 4 equals the measured number at the digits printed; low and high end bracket the measured number.
By their numbers in this assay, from the lowest: compounds 1, 2, 3 and 4 (each within the scatter of the next).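

In this assay, chloro in place of bromo on this aromatic carbon, para to a fused ring, gives no change at the digits printed from compound 1 to compound 4 (within the scatter). Within the data shown here, the earlier step concerned a methyl group elsewhere on the core, so this is the one reading at this position, and here the half-life does not separate bromo from chloro. Nothing measured here offers an explanation for this result.

As far as these compounds go, whether an amine, a carboxylic acid or a longer chain at this position would also stay level remains open. So does whether the same swap reads alike on the core without the methyl group.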